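A few compounds are considered here, and "the series" means these few. Any claim that something is new, unique, unknown or untested is made for them only; others in the source may bear on it.

Of the compounds shown here, three have been measured in a functional assay for agonist activity at G protein-coupled receptor 88 (Homo sapiens), read by HTRF and cAMP accumulation; a higher number here means that more compound is needed for the effect, a lower number that less compound is needed. Compound 1 `CC(C)[C@H](N)CN(C(=O)[C@@H]1C[C@H]1c1ccccc1)c1ccc(-c2ccccc2)cc1` gives 1.1 nM. Among the measured compounds shown here, compound 2 `O=C([C@@H]1C[C@H]1c1ccccc1)N(CC1CCCNC1)c1ccc(-c2ccccc2)cc1` gives 10 nM; the only measured single-point step links these two, with a 9.1-fold higher number from compound 1 to compound 2 (0.96 log units; beyond the scatter). Compound 3 `CC[C@H](C)[C@H](N)CN(C(=O)[C@@H]1C[C@H]1c1cccc(OC)c1)c1ccc(-c2ccccc2)cc1` gives 3000 nM, the highest number of the three, far beyond the scatter from both others, so it needs the most compound for the effect.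

Compound 4 `CC[C@H](C)[C@H](N)CN(C(=O)[C@@H]1C[C@H]1c1ccccn1)c1ccc(-c2ccccc2)cc1` is not yet measured. It differs from compound 3 in one place: pyridin-2-yl in place of 3-methoxyphenyl on a saturated ring carbon. For the measured compounds named here, no measured step in this set concerns a change on that saturated ring carbon; the one measured step, between compound 1 and compound 2, alters a different part of the molecule and therefore gives no guidance on the direction here. With nothing to anchor the change, the expectation is that compound 4 stays near compound 3, and the step of a 1.2-fold lower number from compound 3 to compound 4 (0.08 log units; within the scatter) is estimated with a wide uncertainty in either direction. Compound 4 is therefore expected to give about 2500 nM, with a likely range from 300 nM to 20000 nM.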

Compound 4, half-maximal effective concentration: 130 nM
The estimate for compound 4 lay 19-fold (1.28 log units) above the measured number, outside the stated range (below it).
By their numbers in this assay, from the lowest: compound 1; then compound 2; then compound 4; then compound 3.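

In this assay, the group on the saturated ring carbon of the three-membered ring proves to matter a great deal: pyridin-2-yl in place of 3-methoxyphenyl gives a 23-fold lower number from compound 3 to compound 4 (1.36 log units; beyond the scatter), a step beyond the usual scatter. Among the compounds shown here, this is the first measured change at this position, and it shows that the number responds strongly here, even though one six-membered aromatic ring is replaced by another and the group shrinks only from 8 heavy atoms to 6. No supporting measurement bears on why the number moved.

The pair does not separate the loss of the methoxy group from the gain of the ring nitrogen. Also open, on these data alone, is whether the place of that nitrogen counts, which a pyridin-3-yl or pyridin-4-yl group on the core of compound 4 could address.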